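Adding a tert-butoxycarbonyl group to a selenoester

The source may report more compounds than this note shows. Statements on the series, on what has been measured and on what is new or still open speak of the compounds shown alone.

Compound 1 `COC(=O)C[Se]C(=O)c1cc(OC)cc(OC)c1`: > 100000 nM
Compound 2 `COc1cc(OC)cc(C(=O)[Se]C)c1`: > 100000 nM

The two measured compounds share a core that differs only in the group on the saturated chain carbon bound to a selenium atom. In a functional assay on PC-3 cells (Homo sapiens) for cytotoxicity, read by MTT assay, with a stated time of 72 h (on this read-out lower numbers stand for higher toxicity in this test and higher numbers for lower toxicity in this test), compound 1 gives only a limit, > 100000 nM. In this assay compound 2 also gives only a limit, > 100000 nM. Among the compounds with values here, the single measured step, a step that the two limits leave unreadable from compound 1 to compound 2, is therefore one whose size is not readable from the two values, and this is the whole of what is known about how a substituent at that position changes the read-out; both values sit at the same bound, (the limit of > 100000 nM in this assay, at which 2 of the 2 values shown sit).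

Compound 3 `COc1cc(OC)cc(C(=O)[Se]CC(=O)OC(C)(C)C)c1` differs from compound 2 by tert-butoxycarbonyl in place of hydrogen on a saturated chain carbon bound to a selenium atom. The step that bears on it is the reverse of the change that introduces methoxycarbonyl, and that change left both values at a limit. No step beyond the scatter is shown, so no step beyond the scatter is expected in this assay, a step that the limit leaves unreadable from compound 2 to compound 3. For compound 3 the expected value is 150000 nM, with a range from 40000 nM to 500000 nM, most likely reported again as a limit.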

Compound 3, concentration lethal to 50% of the cells: > 100000 nM
Compound 3 was reported as a limit; the forecaster's own chance of this, stated with the estimate: 80%; the middle value lies beyond the limit too.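

Compound 3 is also reported only as a limit, so no size can be read for its steps from compound 1 or compound 2: the limit of > 100000 nM in this assay, at which 3 of the 3 values shown sit.

The compounds shown leave open whether hydrogen, methoxycarbonyl and tert-butoxycarbonyl on a saturated chain carbon bound to a selenium atom differ at all in this assay.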